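The source may hold more compounds than are shown below. What is called first, only, known or untested is meant among the compounds shown, and "the series" means these compounds.

Measured compounds:
compound 1, `CNc1nnc(-c2nsc3ccccc23)o1`, 10%
compound 2, `CCNc1nnc(-c2nsc3ccccc23)o1`, 53%

Within the data shown here, in a functional assay on the whole organism for inhibition, with Rattus norvegicus as the target, with a stated time of 2 h, at a dose of 100 mg/kg by the oral route (on this read-out lower numbers stand for less inhibition and higher numbers for more inhibition at the one dose given (going by the name of the read-out)), compound 2 stands highest of the two numbers; the only other value, that of compound 1, lies a number 43 percentage points higher from compound 1 to compound 2 (beyond the scatter), a large step for a small change. Compound 3, `Clc1ccc(Nc2nnc(-c3nsc4ccccc34)o2)cc1`, is the unmeasured member of the set. It differs from compound 2 by 4-chlorophenyl in place of ethyl on a nitrogen on an aromatic ring. Among the measured compounds shown here, the one measured step, from compound 1 to compound 2, concerns the same nitrogen and shows that lengthening the chain there raised the number well beyond the scatter; it does not, however, cover a ring entering at that nitrogen, so its bearing on compound 3 is indirect. A step of either direction, or none beyond the scatter, remains possible. Compound 3 is therefore expected to give 40%, within 10% to 80%, which means an expected step of a number 13 percentage points lower from compound 2 to compound 3 (beyond the scatter).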

Compound 3, a percentage reported as inhibition, in the whole organism at one dose (the size of the read-out at that dose, not a potency): 14%
For compound 3 the middle estimate is 26 percentage points above the measured one; measured number inside the range.
By their numbers in this assay, from the lowest: compounds 1 and 3 (each within the scatter of the next); then compound 2.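

In this assay, 4-chlorophenyl in place of ethyl on the nitrogen gives a number 39 percentage points lower from compound 2 to compound 3 (beyond the scatter), so the gain seen from methyl to ethyl does not carry over to this aromatic ring at the same position. Compared with methyl, the same ring gives a number 4 percentage points higher from compound 1 to compound 3 (within the scatter), which leaves compound 2 as the only one of the three standing apart, with the number not rising steadily as the group on this nitrogen grows from methyl through ethyl to 4-chlorophenyl. No measurement at hand offers an explanation for this drop.

On these data alone, it remains open whether a longer chain such as propyl or butyl would hold or exceed the number of compound 2. As far as these compounds go, it is equally open whether plain phenyl or benzyl on this nitrogen would behave like 4-chlorophenyl.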